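A few compounds are considered here, and "the series" means these few. Any claim that something is new, unique, unknown or untested is made for them only; others in the source may bear on it.

Within the data shown here, in a functional assay on ASPC1 cells (Homo sapiens) for antiproliferative activity, read by sulforhodamine B assay, with a stated time of 48 h (on this read-out lower numbers stand for stronger inhibition and higher numbers for weaker inhibition), compound 1 `O=C(CCCCCCN1C(=O)/C(=N\O)c2ccccc21)NO` gives 1100 nM and compound 2 `O=C(CCCCCCN1C(=O)/C(=N\O)c2cc(F)ccc21)NO` gives 1720 nM, so compound 1 stands within the scatter of the only other number. Compound 3 `O=C(CCCCCCN1C(=O)/C(=N\O)c2cc([N+](=O)[O-])ccc21)NO` has nitro in place of hydrogen on an aromatic carbon of the core of compound 1: nitro in place of hydrogen on an aromatic carbon. Among the measured compounds shown here, the only measured step that bears on this is the fluoro replacement of an aromatic hydrogen, a 1.6-fold higher number from compound 1 to compound 2 (0.19 log units; within the scatter). On that single step, no change beyond the scatter is expected in this assay. The expected step is a 1.4-fold higher number from compound 1 to compound 3 (0.13 log units; within the scatter). Compound 3 is estimated at 1500 nM, with an expected range of 600 nM to 3800 nM.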

Compound 3, half-maximal inhibitory concentration: 4680 nM
Estimate against measurement, compound 3: 3.1-fold (0.49 log units) below, outside the stated range (above it).
By their numbers in this assay, from the lowest: compounds 1 and 2 (each within the scatter of the next); then compound 3.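

At this aromatic carbon of the shared core, the series in this assay is not indifferent to what replaces hydrogen: nitro gives a 4.3-fold higher number from compound 1 to compound 3 (0.63 log units; beyond the scatter), whereas fluoro at the same carbon stayed within the scatter. Nitro in place of fluoro gives a 2.7-fold higher number from compound 2 to compound 3 (0.43 log units; beyond the scatter), so the two groups are told apart at this carbon.

Going by these compounds, whether an amine, a methoxy group or a carboxylic acid here would sit with compound 1 or with compound 3 stays open, as does nitro on the other aromatic carbons of the ring. No measurement on hand explains the nitro step.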